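The source may report more compounds than this note shows. Statements on the series, on what has been measured and on what is new or still open speak of the compounds shown alone.

Measured so far:
- compound 1 `Cc1ncc([N+](=O)[O-])n1CCSC(=S)N1CCC(Cc2ccccc2)CC1` — in an ADME assay on HeLa cells (Homo sapiens) for cytotoxicity (on this read-out lower numbers stand for stronger inhibition and higher numbers for weaker inhibition), compound 1 gives > 1000 ug/mL, which is a limit of this assay, not a number.
- compound 2 `Cc1ncc([N+](=O)[O-])n1CCSC(=S)N1CCC(OS(C)(=O)=O)CC1` — in this assay compound 2 gives > 1000 ug/mL, again a limit and not a number.

Compound 2 therefore stands at the limit, together with the other measured compound: the limit of > 1000 ug/mL in this assay, at which 2 of the 2 values shown sit. Among the measured compounds shown here, the one step between measured compounds, a step that the two limits leave unreadable from compound 1 to compound 2, is left unreadable by the two limits, so it gives no usable size or direction for this assay.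

Compound 3 `CCOC(=O)C1CCN(C(=S)SCCn2c([N+](=O)[O-])cnc2C)CC1` differs from compound 2 in one place:
ethoxycarbonyl in place of (methylsulfonyl)oxy on a saturated ring carbon

For the measured compounds named here, no measured step bears readably on this change; the only comparison available is the unreadable one from compound 1 to compound 2. With both measured compounds at the limit of this assay, the expectation for compound 3 is that it likewise stays at or about the limit, with no step beyond the scatter expected: a number no higher from compound 2 to compound 3 (the limit leaves the size open). Compound 3 is estimated at 1000 ug/mL, with a range from 400 ug/mL to 3000 ug/mL, and the assay is expected most likely to report only a limit again.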

Compound 3, half-maximal inhibitory concentration: 510 ug/mL
The estimate for compound 3 lay 2.0-fold (0.29 log units) above the measured number; the measured number falls inside the stated range.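

In this assay, among the compounds shown here, compound 3 gives 510 ug/mL, the first value that is not a limit and so the first readable number for a group on this saturated ring carbon, three ring bonds from the ring nitrogen. Ethoxycarbonyl in place of (methylsulfonyl)oxy gives an at least 1.9-fold lower number from compound 2 to compound 3 (0.29 log units; that floor lies within the scatter), and ethoxycarbonyl in place of benzyl gives an at least 1.9-fold lower number from compound 1 to compound 3 (0.29 log units; that floor lies within the scatter); with both floors within the scatter, neither step alone establishes a real change, and the result shows only that a number can be read with this group in place. Compound 1 and compound 2 remain at a limit, which leaves the true size of both steps open: the limit of > 1000 ug/mL in this assay, at which 2 of the 3 values shown sit.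

The step between compound 1 and compound 2 cannot be read, so no order among benzyl, (methylsulfonyl)oxy and ethoxycarbonyl can be drawn from these compounds. From the compounds shown here alone, how a carboxylic acid or an amine on the same ring carbon, or a longer chain in place of the ethyl part of ethoxycarbonyl, would read in this assay remains open.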